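The compounds below may be only part of what the source reports. "The series", "measured", "known", "first", "only" and "open" are said of these compounds alone.

Compound 1, `COc1cc2c(Nc3nc4ccc(C(=O)Nc5c(C)cccc5C)cc4s3)ncnc2cc1OCCCN1CCCC1`, gives in a functional assay on NCI-H661 cells (Homo sapiens) for cytotoxicity, read by WST assay, with a stated time of 72 h (on this read-out lower numbers stand for stronger inhibition and higher numbers for weaker inhibition), the value > 100000 nM, which is a limit of the assay and not a number.
Compound 2, `COc1cc2c(Nc3nc4ccc(C(=O)Nc5c(C)cccc5C)cc4s3)ncnc2cc1OCCCN1CCCCC1`, gives in this assay the value > 100000 nM, again a limit of the assay.
Compound 3, `COc1cc2c(Nc3nc4ccc(C(=O)Nc5c(C)cc(C)cc5C)cc4s3)ncnc2cc1OCCCN1CCCCC1`, gives in this assay the value 10000 nM.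

All three share the same core, and two changes are made to it. From compound 2 to compound 3 the change is methyl in place of hydrogen on an aromatic carbon; this gives an at least 10-fold lower number from compound 2 to compound 3 (1.00 log units; beyond the scatter). From compound 2 to compound 1 the change is pyrrolidin-1-yl in place of piperidin-1-yl on a saturated chain carbon, three bonds along the chain from an oxygen on an aromatic ring; here the step is a step that the two limits leave unreadable from compound 2 to compound 1, because of the limit of > 100000 nM in this assay, at which 2 of the 3 values shown sit.

Compound 4, `COc1cc2c(Nc3nc4ccc(C(=O)Nc5c(C)cc(C)cc5C)cc4s3)ncnc2cc1OCCCN1CCCC1`, has not yet been measured. It differs from compound 3 by pyrrolidin-1-yl in place of piperidin-1-yl on a saturated chain carbon, three bonds along the chain from an oxygen on an aromatic ring. The place of this change is the same, word for word, as the place of the change from compound 2 to compound 1, so it is the same change made on a different core; the core of compound 3 differs from that of compound 2 by the methyl just described.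

Among the measured compounds shown here, the one earlier instance of this change left no readable size, since both of its compounds sit at a limit. The expectation for compound 4 therefore rests mainly on the value of compound 3, 10000 nM, and on the ring swap being a modest one that keeps the same kind of group at the same place. In this assay the step from compound 3 to compound 4 is estimated at a 1.5-fold higher number from compound 3 to compound 4 (0.18 log units; within the scatter). Compound 4 is expected to give about 15000 nM, within an estimated range of 4000 nM to 100000 nM.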

Compound 4, half-maximal inhibitory concentration: 9600 nM
The estimate for compound 4 lay 1.6-fold (0.19 log units) above the measured number; the range from low to high includes it.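

In this assay, methyl in place of hydrogen on an aromatic carbon gives an at least 10-fold lower number from compound 1 to compound 4 (1.01 log units; beyond the scatter), which points the same way as the same change made on the core carrying piperidin-1-yl: the same change on two cores in this assay, an at least 10-fold lower number (1.00 log units; beyond the scatter) from compound 2 to compound 3 and an at least 10-fold lower number (1.01 log units; beyond the scatter) from compound 1 to compound 4; the limit leaves it open whether they differ

The ring swap, pyrrolidin-1-yl in place of piperidin-1-yl, gives a 1.0-fold lower number from compound 3 to compound 4 (0.02 log units; within the scatter), so on the core of compound 3 the two rings cannot be told apart in this read-out. What stays unshown is the true size of either methyl step, and whether the ring swap behaves alike on the core of compound 2, since the values of compound 1 and compound 2 are limits and not numbers, which leaves those steps unreadable: the limit of > 100000 nM in this assay, at which 2 of the 4 values shown sit.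

The compounds shown leave open whether a group other than methyl on that aromatic carbon, such as chloro or methoxy, would lower the number as well. They also leave open what a morpholin-4-yl or dimethylamino group in place of these rings, or a longer chain than 3-(pyrrolidin-1-yl)propyl, would do on the core of compound 3.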